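The source may report more compounds than this note shows. Statements on the series, on what has been measured and on what is new or still open speak of the compounds shown alone.

Among the measured compounds shown here, in a functional assay on HT-29 cells (Homo sapiens) for inhibition, read by CCK-8 assay, with a stated time of 24 h (on this read-out higher numbers stand for weaker inhibition and lower numbers for stronger inhibition), compound 1 `Cc1cccc(-n2cc(-c3ccc(/C=C4\C(=O)Nc5ccccc54)cc3)nn2)c1` gives 3940 nM, the lower of the two numbers measured so far. The other measured compound, compound 2 `O=C1Nc2ccccc2/C1=C/c1ccc(-c2cn(-c3ccccc3F)nn2)cc1`, gives 10500 nM. For the measured compounds named here, the one measured step between them is a 2.7-fold higher number from compound 1 to compound 2 (0.43 log units; beyond the scatter), a modest loss of inhibition that comes with 2-fluorophenyl in place of 3-methylphenyl on an aromatic nitrogen. Compound 3 `Cc1cccc(-n2cc(-c3ccc(/C=C4\C(=O)Nc5ccc(F)cc54)cc3)nn2)c1` keeps the 3-methylphenyl group and changes the molecule elsewhere: fluoro in place of hydrogen on an aromatic carbon. This is fluoro in place of hydrogen on an aromatic carbon, on a six-membered aromatic ring of carbon only that is part of a fused or bridged system of two rings. The measured step also involves a fluorine, but at a different place, so it bears on this change only loosely. Going by the values given here, no measured compound shows what fluoro does at this place, which leaves no firm basis for predicting a direction. The modest step from compound 1 to compound 2 offers only a rough guide to size, so no shift beyond the scatter is expected in this assay. The estimated result is a 1.1-fold lower number from compound 1 to compound 3 (0.05 log units; within the scatter). Compound 3 is expected at about 3500 nM, with an estimated range from 1500 nM to 8500 nM.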

Compound 3, half-maximal inhibitory concentration: 7320 nM
Compound 3: the middle estimate sits 2.1-fold (0.32 log units) below what was measured, and the stated range covers the measured number.
By their numbers in this assay, from the lowest: compounds 1, 3 and 2 (each within the scatter of the next, the first and the last beyond it).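

Among the compounds shown here, this is the first look at the shared core away from the aromatic group on nitrogen. In this assay, the change shows a 1.9-fold higher number from compound 1 to compound 3 (0.27 log units; within the scatter), so compound 3 cannot be told apart from compound 1 on this read-out, whereas the earlier change on the nitrogen-bound ring gave a 2.7-fold higher number from compound 1 to compound 2 (0.43 log units; beyond the scatter), which lies beyond the scatter. A single fluoro on this aromatic carbon of the fused two-ring system is therefore accepted without a clear loss or gain of inhibition in these cells, although nothing available accounts for this outcome or shows what the compounds do inside the cells.

As far as these compounds go, one small atom at one carbon says little about the position as a whole, so it remains open whether a larger or differently natured group there, such as chloro, methoxy, an amine or a carboxylic acid, would leave the number equally unmoved or shift it beyond the scatter. From the compounds shown here alone, it also remains open how fluoro behaves on the other carbons of this ring, and whether it would give a similar result when paired with the 2-fluorophenyl group instead of the 3-methylphenyl group.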